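Working notes on four benzyl variants of one core

This account rests on a few compounds, and the source may have more. Where it says the series, first, only, none or still open, it means among the compounds named here.

Values in a functional assay on MCF7 cells (Homo sapiens) for cytotoxicity, read by MTT assay, with a stated time of 72 h; a lower number here means a stronger inhibitor, a higher number a weaker inhibitor:

compound 1 `CCNC(=O)N1CCN(C(=S)SCc2cn(Cc3ccc(F)cc3)nn2)CC1` — 3660 nM
compound 2 `CCNC(=O)N1CCN(C(=S)SCc2cn(Cc3ccc(Cl)cc3)nn2)CC1` — a limit, > 128000 nM
compound 3 `CCNC(=O)N1CCN(C(=S)SCc2cn(Cc3ccc(C)cc3)nn2)CC1` — a limit, > 128000 nM

Compound 3 stands at the limit of the assay: for compound 3 this assay returns only > 128000 nM, not a number. Compound 2 sits at the same limit with > 128000 nM. For the measured compounds named here, compound 1 is the one measured value, 3660 nM, so both known steps run from it: an at least 34-fold higher number from compound 1 to compound 2 (1.54 log units; beyond the scatter) and an at least 34-fold higher number from compound 1 to compound 3 (1.54 log units; beyond the scatter). The step that the two limits leave unreadable from compound 2 to compound 3 cannot be sized, because of the limit of > 128000 nM in this assay, at which 2 of the 3 values shown sit.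

Compound 4 `CCNC(=O)N1CCN(C(=S)SCc2cn(Cc3ccc(OC)cc3)nn2)CC1` differs from compound 3 by methoxy in place of methyl on an aromatic carbon. Going by the values given here, no measured pair swaps methyl for methoxy, so only the unreadable step from compound 2 to compound 3 bears on it; the two large steps away from compound 1 show that changes at this position can move the value far, but in which direction here is not readable. Compound 4 is therefore expected near 90000 nM, with a wide range from 15000 nM to 200000 nM. The expected step is an at least 1.4-fold lower number from compound 3 to compound 4 (0.15 log units; that floor lies within the scatter).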

Compound 4, half-maximal inhibitory concentration: 97600 nM
The estimate for compound 4 lay 1.1-fold (0.04 log units) below the measured number; measured number inside the range.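

Methoxy is the first replacement of fluoro at this position that returns a number rather than a limit in this assay. Against the two compounds held at a limit, the result reads as an at least 1.3-fold lower number from compound 3 to compound 4 (0.11 log units; that floor lies within the scatter) and an at least 1.3-fold lower number from compound 2 to compound 4 (0.11 log units; that floor lies within the scatter), so these floors do not set methoxy apart from methyl or chloro. The large step of a 27-fold higher number from compound 1 to compound 4 (1.43 log units; beyond the scatter) shows that a measurable value does not bring the series back near compound 1, which leaves fluoro alone among the four groups shown at the lower number.

From the compounds shown here alone, the step between compound 2 and compound 3 stays unreadable because of the shared limit: the limit of > 128000 nM in this assay, at which 2 of the 4 values shown sit. Whether an amino group, a hydroxy group or a trifluoromethyl group at this position would fall near compound 1 or near compound 4 remains open.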